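This account rests on a few compounds, and the source may have more. Where it says the series, first, only, none or still open, it means among the compounds named here.

Series built on the shared core of compound 1 `CCCCCC(=O)Nc1cc2nc(C3CCCCC3)[nH]c2cc1N1CCCC1`, compound 2 `CN(C)c1cc2[nH]c(C3CCCCC3)nc2cc1NC(=O)c1ccc(Br)cc1` and compound 3 `CCCNC(=O)Nc1cc2nc(C3CCCCC3)[nH]c2cc1N1CCCC1`, all tested in an ADME assay on Vero cells (Chlorocebus sabaeus) for cytotoxicity, read by resazurin assay, with a stated time of 3 days; on this read-out higher numbers stand for weaker inhibition and lower numbers for stronger inhibition. In this assay compound 1 gives only a limit, > 100 ug/mL. In this assay compound 2 gives only a limit, > 100 ug/mL. In this assay compound 3 gives only a limit, > 100 ug/mL. Compound 3 thus stands where every other value in the set stands, as summarised by the limit of > 100 ug/mL in this assay, at which 3 of the 3 values shown sit. For the measured compounds named here, the one step between neighbours, a step that the two limits leave unreadable from compound 1 to compound 3, is left unreadable by the two limits. The next compound, compound 4 `O=C(Nc1cc2nc(C3CCCCC3)[nH]c2cc1N1CCCC1)c1ccc(Br)cc1`, differs from compound 3 by 4-bromophenyl in place of propylamino on a carbonyl carbon. Compound 2 carries the same 4-bromophenyl on its carbonyl carbon and also sits at the limit in this assay. Going by the values given here, no measured step gives a size for this change; all that is known is that every value so far sits at the limit. Compound 4 is therefore expected to sit at the limit too, with a step of a number no higher from compound 3 to compound 4 (the limit leaves the size open) expected to be nothing beyond the scatter. The estimate for compound 4 in this assay is 100 ug/mL, within 50 ug/mL to 300 ug/mL.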

Compound 4, half-maximal inhibitory concentration: > 100 ug/mL
Compound 4 was reported as a limit; the forecaster's own chance of this, stated with the estimate: 85%; the middle value sits exactly at the limit.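

In this assay compound 4 gives > 100 ug/mL as a limit of the assay. Its steps from compound 1, compound 2 and compound 3 cannot be read. The compounds shown leave open whether any change on the shared core brings a measurable cytotoxicity, with every value at one limit: the limit of > 100 ug/mL in this assay, at which 4 of the 4 values shown sit.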